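The source may hold more compounds than are shown below. What is called first, only, known or untested is meant among the compounds shown, and "the series" means these compounds.

Measured compounds:
compound 1 `COc1cc(/C=C/C(=O)OCCCCCCO[N+](=O)[O-])ccc1O` in a functional assay on H266 cells (Homo sapiens) for cytotoxicity, read by resazurin assay, with a stated time of 72 h (a higher number here means a weaker inhibitor, a lower number a stronger inhibitor), gives > 50000 nM, which is only a limit of the assay.
compound 2 `COc1cc(/C=C/C(=O)OC(C)C)ccc1O` in this assay gives > 50000 nM, again only a limit.

Compound 2 therefore has no number in this assay, only a limit, and compound 1 sits at the same limit (the limit of > 50000 nM in this assay, at which 2 of the 2 values shown sit). Compound 3 `COc1cc(/C=C/C(=O)OCCCO[N+](=O)[O-])ccc1O` carries 3-(nitrooxy)propyl in place of isopropyl on an oxygen next to a carbonyl group. No measured step joins any two of these compounds, so what follows rests on the two limits alone. With compound 1 and compound 2 both at the limit, compound 3 is expected to remain there as well, a step of a number no higher from compound 2 to compound 3 (the limit leaves the size open) of no size beyond the scatter. Compound 3 is estimated at 50000 nM, within 20000 nM to 120000 nM.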

Compound 3, half-maximal inhibitory concentration: 44000 nM
Estimate against measurement, compound 3: 1.1-fold (0.06 log units) above, and the stated range covers the measured number.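

In this assay, among the compounds shown here, compound 3 gives 44000 nM, the first actual number for a group on an oxygen next to a carbonyl group. The change from isopropyl to 3-(nitrooxy)propyl is an at least 1.1-fold lower number from compound 2 to compound 3 (0.05 log units; that floor lies within the scatter), and the change in chain length is an at least 1.1-fold lower number from compound 1 to compound 3 (0.05 log units; that floor lies within the scatter). Both steps are only floors, so their true sizes remain unknown, and the other values stay at a limit: the limit of > 50000 nM in this assay, at which 2 of the 3 values shown sit.

It remains open whether the nitrooxy group contributes to the number in compound 3, since a plain propyl chain is not among the compounds shown. On these data alone, how an amine or a carboxylic acid at the end of that chain would read in this assay also remains open.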